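The source may report more compounds than this note shows. Statements on the series, on what has been measured and on what is new or still open speak of the compounds shown alone.

Measured in an ADME assay on Raji cells (Homo sapiens) for cytotoxicity, with a stated time of 72 h; a higher number here means that more compound is needed for the effect, a lower number that less compound is needed:
- Compound 1 `O=C(Nc1ccc(O)c(-c2nc3ccccc3s2)c1)c1cc([N+](=O)[O-])ccc1Cl`: > 25000 nM, a limit
- Compound 2 `O=C(Nc1nc(-c2ccc(Cl)cc2)cs1)c1cc([N+](=O)[O-])ccc1Cl`: 12000 nM
- Compound 3 `O=C(Nc1cccc(-c2nc3ccccc3s2)c1)c1cc([N+](=O)[O-])ccc1Cl`: > 27000 nM, a limit

Among the measured compounds shown here, compound 2 holds the only actual number in the set, as the other two values are limits. Compound 4 `O=C(Nc1nc(-c2cccc(F)c2)cs1)c1cc([N+](=O)[O-])ccc1Cl` differs from it by 3-fluorophenyl in place of 4-chlorophenyl on an aromatic carbon. For the measured compounds named here, the only measured step, a step that the two limits leave unreadable from compound 1 to compound 3, concerns hydrogen in place of hydroxy and has no readable size, so no measured step bears on this change. The starting point therefore remains compound 2 at 12000 nM in this assay. The expected change, a 1.2-fold higher number from compound 2 to compound 4 (0.07 log units; within the scatter), stays within the scatter, with no direction favoured. For compound 4 the estimated value is 14000 nM, with an expected range of 6000 nM to 30000 nM.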

Compound 4, half-maximal effective concentration: 11000 nM
For compound 4 the middle estimate is 1.3-fold (0.10 log units) above the measured one; the measured number falls inside the stated range.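

In this assay, among the compounds shown here, the change at this position gives a 1.1-fold lower number from compound 2 to compound 4 (0.04 log units; within the scatter), the first step in the set with a readable size. On the aromatic carbon next to the ring nitrogen, 3-fluorophenyl cannot be told apart from 4-chlorophenyl, although this one change swaps the halogen and moves it on the phenyl ring, so the two effects cannot be separated. Nothing at hand gives a reason for this result.

The compounds shown leave open whether a plain phenyl, or a phenyl carrying a methoxy group or an amine, would read differently here. They also leave open what the halogen and its place on the phenyl ring each contribute alone.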